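The compounds below may be only part of what the source reports. "The series", "measured", "known", "first", "only" and "open" are said of these compounds alone.

Measured so far in a functional assay on LNCaP cells (Homo sapiens) for antiproliferative activity; a lower number here means a stronger inhibitor, a higher number a weaker inhibitor:
- Compound 1 `Cn1ncc(Cl)c1-c1cc(C(=O)N[C@@H]2CN[C@H](CCO)C[C@H]2c2ccc(Cl)c(Cl)c2)oc1Cl`: 160 nM
- Compound 2 `Cn1ncc(Cl)c1-c1cc(C(=O)N[C@@H]2CN[C@H](CCN3CCCC3)C[C@H]2c2ccc(Cl)c(Cl)c2)oc1Cl`: 1920 nM

Compound 2 has the higher of these two numbers, which makes it the weaker inhibitor of the pair. The next compound, compound 3 `Cn1ncc(Cl)c1-c1cc(C(=O)N[C@@H]2CN[C@H](CC(=O)NCCO)C[C@H]2c2ccc(Cl)c(Cl)c2)oc1Cl`, has not yet been measured. Its structure brings (2-hydroxyethyl)carbamoyl in place of (pyrrolidin-1-yl)methyl on a saturated chain carbon bound to a saturated ring carbon. The pyrrolidine ring is therefore gone, and the new chain ends in a hydroxy group, as the chain of compound 1 does.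

Going by the values given here, only one measured step bears on this change: a 12-fold higher number from compound 1 to compound 2 (1.08 log units; beyond the scatter). It is a large step, beyond the scatter, and it came with pyrrolidin-1-yl in place of hydroxy. Among the compounds with values here, compound 3 partly reverses that swap, but it also carries a carbamoyl group, and no measured compound shows what this adds. A partial return is therefore expected in this assay, smaller than the measured step and towards a lower number, with an estimated 4.3-fold lower number from compound 2 to compound 3 (0.63 log units; beyond the scatter). For compound 3 the estimated value is 450 nM, with an expected range of 130 nM to 1500 nM.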

Compound 3, half-maximal inhibitory concentration: 40 nM
Compound 3: the middle estimate sits 11-fold (1.05 log units) above what was measured; measured number outside the range, below it.
By their numbers in this assay, from the lowest: compound 3; then compound 1; then compound 2.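

In this assay the exchange of (pyrrolidin-1-yl)methyl for (2-hydroxyethyl)carbamoyl gives a 48-fold lower number from compound 2 to compound 3 (1.68 log units; beyond the scatter) and so more than recovers what was lost in a 12-fold higher number from compound 1 to compound 2 (1.08 log units; beyond the scatter) at this chain. Compound 3 is also no mere return to the hydroxy-ended chain, for the comparison with the shorter chain of compound 1 gives a 4.0-fold lower number from compound 1 to compound 3 (0.60 log units; beyond the scatter) and shows that this position can carry a larger group with a carbamoyl in it and still gain, a modest step but one beyond the scatter. No measurement here accounts for either step, so the reason for the gain remains unknown.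

The carbamoyl and the hydroxy end enter together, so the compounds shown do not tell which of the two matters, or whether both are needed. A primary amide or a carboxylic acid on the same saturated chain carbon, or a methoxy in place of the final hydroxy, would begin to separate these two parts.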